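Series notes: hydroxy in place of fluoro

A few compounds are considered here, and "the series" means these few. Any claim that something is new, unique, unknown or untested is made for them only; others in the source may bear on it.

compound 1 `O=C1OC(c2ccc(F)cc2)C(c2ccc(O)cc2)=C1O` — 0%
compound 2 `O=C1OC(c2ccc(OCc3ccccc3)c(OCc3ccccc3)c2)C(c2ccc(F)cc2)=C1O` — 0%

In an assay on blood for inhibition of Polyunsaturated fatty acid 5-lipoxygenase (Homo sapiens), tested at 10 uM (a lower number here means a weaker effect, a higher number a stronger effect of the compound at the concentration tested), compound 1 gives 0% and compound 2 gives 0%. Compound 1 stands level with compound 2 at the digits shown, with no change beyond the scatter. Within the data shown here, no step between measured compounds is known. Compound 3 `O=C1OC(c2ccc(O)cc2)C(c2ccc(O)cc2)=C1O` is not yet measured; it differs from compound 1 by hydroxy in place of fluoro on an aromatic carbon.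

Because compound 1 gives 0% and compound 2 gives 0%, no step beyond the scatter is expected in this assay. The expected step is a number 3 percentage points higher from compound 1 to compound 3 (within the scatter). Compound 3 is expected to give 3%, within a range from 0% to 15%.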

Compound 3, a percentage reported as activity, at one concentration (the size of the read-out at that concentration, not a potency): 0%
For compound 3 the middle estimate is 3 percentage points above the measured one; measured number inside the range.
By their numbers in this assay, from the lowest: compounds 1, 2 and 3 (each within the scatter of the next).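

Exchanging fluoro for hydroxy on the aromatic carbon, para to a large group, gives in this assay no change at the digits printed from compound 1 to compound 3 (within the scatter). Among these compounds, this 4-fluorophenyl to 4-hydroxyphenyl change is therefore the first single-place comparison, and it leaves the read-out level even with the 4-hydroxyphenyl group now present twice. No supporting data bear on this result.

With every reading level, the compounds shown cannot tell whether this position influences the read-out at all. Going by these compounds, whether an amine or a carboxylic acid here would raise the read-out remains open.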